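From chloro to pyridin-3-yl in compound 4

A few compounds are considered here, and "the series" means these few. Any claim that something is new, unique, unknown or untested is made for them only; others in the source may bear on it.

Measured so far in a physicochemical assay for lipophilicity, using the shake flask method, in phosphate buffer, measured as octanol-water partition, with a stated time of 1 h, at pH 7.4; on this read-out higher numbers stand for higher lipophilicity and lower numbers for lower lipophilicity:
compound 1 `CCNC(=O)Nc1cc(Cl)c(-c2cncc(C(=O)O)c2)cn1` gives -1.1
compound 2 `CCNC(=O)Nc1cc(-c2nc(C(F)(F)F)cs2)c(-c2cncc(C(N)=O)c2)cn1` gives 2
compound 3 `CCNC(=O)Nc1cc(Br)c(-c2cncc(C(=O)O)c2)cn1` gives -1

Compound 1 shares the low end of these numbers with compound 3, and the two lie within the scatter of each other. Compound 2 stands far from both with 2 as its number.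

Still unmeasured is compound 4 `CCNC(=O)Nc1cc(-c2cccnc2)c(-c2cncc(C(=O)O)c2)cn1` which keeps the rest of compound 1 and differs from it at one place. That difference is pyridin-3-yl in place of chloro on an aromatic carbon and in short it puts pyridin-3-yl in place of chloro on an aromatic carbon.

Within the data shown here, the only measured step at this place is a number 0.10 log units higher from compound 1 to compound 3 (within the scatter) and it exchanges chloro for bromo. Among the measured compounds shown here, no measured step shows a ring entering there from compound 1, so the guide is weak and the direction stays open. Resting on compound 3 and its step of a number 0.10 log units higher from compound 1 to compound 3 (within the scatter) the account expects no shift beyond the scatter. The estimated step is a number 0.10 log units lower from compound 1 to compound 4 (within the scatter) in this assay and stays an expectation. For compound 4 the expected value is -1.2 with an estimated range from -1.8 to -0.6 until the measurement is known.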

Compound 4, distribution coefficient: -1.5
Compound 4: middle estimate off by 0.30 log units, on the high side; the range from low to high includes it.
By their numbers in this assay, from the lowest: compound 4; then compounds 1 and 3 (each within the scatter of the next); then compound 2.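

In this assay, the only earlier step at this position was a number 0.10 log units higher from compound 1 to compound 3 (within the scatter) with bromo in place of chloro, so the position had shown no shift beyond the scatter. With pyridin-3-yl on the aromatic carbon opposite the ring nitrogen, a ring enters there and the result is a number 0.40 log units lower from compound 1 to compound 4 (beyond the scatter) with chloro leaving, and a number 0.50 log units lower from compound 3 to compound 4 (beyond the scatter) with bromo leaving, the first shifts at this position beyond the scatter. Both steps are modest and point the same way, so among these three compounds, which all carry the same carboxylic acid, the ring stands lower than either halogen despite its larger count of heavy atoms, and no measurement at hand gives a reason for this.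

Whether the lower number belongs to pyridin-3-yl in particular or to any ring at this position stays open, since a phenyl ring, a pyridin-2-yl group or an amine is not among the compounds shown. Compound 2 differs from compound 4 in more than one place, so it cannot show whether the same step would hold with the primary amide of compound 2 in place of the carboxylic acid.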